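The source may report more compounds than this note shows. Statements on the series, on what has been measured and on what is new or still open speak of the compounds shown alone.

Working notes on the series. Among the measured compounds shown here, compound 2 `CC1=C(C(=O)C2CC2)C(c2ccco2)NC(=O)N1` stands highest of the two numbers so far in an assay on membranes from HEK293 cells for displacement of a labelled ligand from adenosine receptor A2b (Homo sapiens), read by scintillation counting, with a stated time of 30 min (a lower number here means a stronger inhibitor, a higher number a weaker inhibitor), giving 1060 nM; its nearest neighbour, compound 1 `CC1=C(C(=O)OCC(C)C)C(c2ccoc2)NC(=O)N1`, gives 326 nM, a gap beyond the scatter. Compound 3 `CC1=C(C(=O)OC2CCCC2)C(c2ccco2)NC(=O)N1` is not yet measured; it differs from compound 2 by cyclopentyloxy in place of cyclopropyl on a carbonyl carbon. For the measured compounds named here, no measured pair isolates this change. Compound 1 already carries an oxygen on that carbonyl carbon and gives 326 nM, so in this assay the step is expected to run toward a lower number, moderate in size, a 2.7-fold lower number from compound 2 to compound 3 (0.42 log units; beyond the scatter). Compound 3 is expected at 400 nM, within 130 nM to 1200 nM.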

Compound 3, inhibition constant: 577 nM
The estimate for compound 3 lay 1.4-fold (0.16 log units) below the measured number; the measured number falls inside the stated range.
By their numbers in this assay, from the lowest: compounds 1, 3 and 2 (each within the scatter of the next, the first and the last beyond it).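

In this assay cyclopentyloxy in place of cyclopropyl on a carbonyl carbon gives a 1.8-fold lower number from compound 2 to compound 3 (0.26 log units; within the scatter) and is the first single change isolated among the compounds shown. This position thus accepts the larger ring with its added oxygen, with no shift that can be told from the scatter. No evidence at hand bears on this result.

Still open, as far as these compounds go, is how an amine on the same carbonyl carbon, or a longer straight chain on the oxygen, would read in this assay.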